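The source may hold more compounds than are shown below. What is called first, only, known or untested is meant among the compounds shown, and "the series" means these compounds.

Measured in a functional assay on HCT-116 cells (Homo sapiens) for inhibition, read by sulforhodamine B assay, with a stated time of 48 h, tested at 50 uM; a higher number here means more inhibition of growth at the concentration tested, a lower number less inhibition of growth:
- compound 1 `COc1cc(/C=C/C(=O)/C=C/c2cccs2)ccc1OCc1cn(CCCCCOc2cc(=O)oc3ccccc23)nn1`: 31%
- compound 2 `COc1cc(/C=C/C(=O)/C=C/c2cc(OC)c(OC)c(OC)c2)ccc1OCc1cn(CCOc2cc(=O)oc3ccccc23)nn1`: 89%
- compound 3 `COc1ccc(/C=C/C(=O)/C=C/c2ccc(OCc3cn(CCOc4cc(=O)oc5ccccc45)nn3)c(OC)c2)cc1OC`: 82%

Not yet measured: compound 4 `COc1ccc(/C=C/C(=O)/C=C/c2ccc(OCc3cn(CCOc4cc(=O)oc5ccccc45)nn3)c(OC)c2)cc1`.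

Compound 3, at 82%, lies within the scatter of compound 2 and well clear of compound 1, whose 31% is beyond the scatter from it. The next step is hydrogen in place of methoxy on an aromatic carbon, turning 3,4-dimethoxyphenyl into 4-methoxyphenyl, with the replaced methoxy ortho to a methoxy group and meta to a large group.

Going by the values given here, one measured step bears on this, as it is also hydrogen in place of methoxy on an aromatic carbon: a number 7 percentage points lower from compound 2 to compound 3 (within the scatter). Compound 1 differs from compound 3 in more than one place, so it gives no guide to this single exchange. One step is thin evidence, and the data do not show whether a further methoxy loss would behave alike. The working expectation is therefore a small step in this assay, slightly downward if anything and probably none beyond the scatter.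

The estimated change is a number 4 percentage points lower from compound 3 to compound 4 (within the scatter).

The expected value for compound 4 is 78%, with an estimated range of 64% to 90%.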

Compound 4, percent growth inhibition at one concentration: 71%
Beside the measured number, compound 4's estimate is 7 percentage points above it; the measured number falls inside the stated range.
By their numbers in this assay, from the lowest: compound 1; then compound 4; then compounds 3 and 2 (each within the scatter of the next).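

In this assay the exchange of hydrogen for methoxy now has a visible effect: a number 11 percentage points lower from compound 3 to compound 4 (beyond the scatter) is read for the methoxy ortho to a methoxy group, whereas a number 7 percentage points lower from compound 2 to compound 3 (within the scatter) was read for the earlier loss of a methoxy from the 3,4,5-trimethoxyphenyl group. The full change from 3,4,5-trimethoxyphenyl to 4-methoxyphenyl gives a number 18 percentage points lower from compound 2 to compound 4 (beyond the scatter) and shows that this end of the molecule is not indifferent to its methoxy groups, although compound 4 still gives 71% at the single concentration tested. No measurement on hand accounts for the difference between the two methoxy exchanges.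

The compounds shown leave open whether the remaining 4-methoxy group contributes at all, as a plain phenyl group or a hydroxyl, an amine or a carboxylic acid at that place would test. They also leave open whether the same exchange gives a step of similar size when the chain to the triazole is a longer chain.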